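This account rests on a few compounds, and the source may have more. Where it says the series, first, only, none or still open, it means among the compounds named here.

Of the compounds shown here, two built on one shared core have been tested in an assay on CHO cells for displacement of a labelled ligand from adenosine receptor A1 (Homo sapiens), read by scintillation counting, with a stated time of 90 min, tested at 1 uM, in the presence of a further agent that is not named here; a lower number here means less inhibition, a higher number more inhibition at the concentration tested (going by the name of the read-out). Compound 1 `CCCn1c(=O)[nH]c2nc(-c3ccc(S(=O)(=O)N4CCN(c5cccc(Cl)c5)CC4)cc3)[nH]c2c1=O` gives 21% in this assay, and compound 2 `CCCn1c(=O)[nH]c2nc(-c3ccc(S(=O)(=O)N4CCN(c5ccc(C)cc5)CC4)cc3)[nH]c2c1=O` gives 12%. They differ only in the group on an amine nitrogen in a ring, and the step was a number 9 percentage points lower from compound 1 to compound 2 (within the scatter). On the numbers shown, compound 2 stands at the bottom of the pair, with compound 1 its sole neighbour, but the gap between them is within the scatter, so the two cannot be told apart.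

Compound 3 `CCCn1c(=O)[nH]c2nc(-c3ccc(S(=O)(=O)N4CCN(C(C)c5ccccc5)CC4)cc3)[nH]c2c1=O` alters that same place: 1-phenylethyl in place of 4-methylphenyl on an amine nitrogen in a ring. For the measured compounds named here, the single measured step at this nitrogen, the swap of 3-chlorophenyl for 4-methylphenyl, moved the read-out by too little to count, so nothing measured points to a shift beyond the scatter here. Compound 3 is therefore expected to sit close to compound 2, with an expected step of a number 3 percentage points higher from compound 2 to compound 3 (within the scatter). The estimate for compound 3 is 15%, with a range from 0% to 35%.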

Compound 3, a percentage reported as inhibition, at one concentration (the size of the read-out at that concentration, not a potency): 42%
The estimate for compound 3 lay 27 percentage points below the measured number, and the stated range ends below it.
By their numbers in this assay, from the lowest: compounds 2 and 1 (each within the scatter of the next); then compound 3.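

This nitrogen is not indifferent to the group it carries: in this assay, the change to 1-phenylethyl gives a number 30 percentage points higher from compound 2 to compound 3 (beyond the scatter) and also a number 21 percentage points higher from compound 1 to compound 3 (beyond the scatter). For the compounds shown here, the earlier swap of 3-chlorophenyl for 4-methylphenyl gave no step beyond the scatter, so this is the first sign that a change here can move the read-out, even though 4-methylphenyl and 1-phenylethyl each hold one six-membered aromatic ring of carbon only and no net charge. No measurement at hand says what lies behind the rise.

Still open, as far as these compounds go, is whether a plain benzyl group or a longer chain such as 2-phenylethyl would keep the higher number at this nitrogen. Also open, from the compounds shown here alone, is whether a ring without aromatic character, such as cyclohexyl, would do the same.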